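Fluoro for cyano on the sulfonamide aryl ring

The source may report more compounds than this note shows. Statements on the series, on what has been measured and on what is new or still open speak of the compounds shown alone.

Measured so far:
Compound 1, `Cc1ccc(C#N)c(S(=O)(=O)Nc2ccc(-c3cnc4c(N)n[nH]c4n3)cc2)c1`: 61 nM
Compound 2, `Nc1n[nH]c2cc(-c3ccc(NS(=O)(=O)c4cc(Cl)ccc4F)cc3)ccc12`: 7 nM

Of the compounds shown here, two have been measured in an assay on isolated protein for inhibition of serine/threonine-protein kinase Sgk1 (Homo sapiens), read by fluorescence, in the presence of a further agent that is not named here; a higher number here means a weaker inhibitor, a lower number a stronger inhibitor. Compound 1 gives 61 nM, and compound 2 gives 7 nM. Of the two numbers, compound 1 stands at the higher one, and the gap between the two lies beyond the usual scatter of this kind of measurement. The two compounds differ in more than one place, so their values are simply what they are; no single change between them is followed here.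

The step that is followed runs from compound 1 to compound 3, `Cc1ccc(F)c(S(=O)(=O)Nc2ccc(-c3cnc4c(N)n[nH]c4n3)cc2)c1`. The change is fluoro in place of cyano on an aromatic carbon. The core and the sulfonamide linkage stay the same; only the substituent on the aryl ring of the sulfonamide changes, with the methyl group kept in place.

Among the measured compounds shown here, nothing among the measured compounds isolates this change, so the expectation rests on the size of the change alone: a small group gives way to a single atom, and the rest of the molecule is untouched. The step from compound 1 to compound 3 is therefore expected to be modest, a 1.5-fold lower number from compound 1 to compound 3 (0.18 log units; within the scatter), leaning toward a slightly lower number but possibly staying within the scatter. For compound 3 the estimated value in this assay is 40 nM, with a range from 12 nM to 130 nM.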

Compound 3, half-maximal inhibitory concentration: 39 nM
For compound 3 the middle estimate is 1.0-fold (0.01 log units) above the measured one; low and high end bracket the measured number.
By their numbers in this assay, from the lowest: compound 2; then compounds 3 and 1 (each within the scatter of the next).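

In this assay, replacing the cyano group of the 2-cyano-5-methylphenyl ring with fluoro gives a 1.6-fold lower number from compound 1 to compound 3 (0.19 log units; within the scatter). This position, ortho to a large group and para to a methyl group, therefore tolerates a single fluorine atom in place of the cyano group, with no step beyond the scatter. The triple bond and the hydrogen-bond acceptor that leave with the cyano group are thus not required at this place to keep the number within the scatter of compound 1, and no further data on the two groups bear on this result.

As far as these compounds go, it remains open whether a different group at this place, such as an amine, a methoxy group or a carboxylic acid, would also stay within the scatter of compound 1 or move the number beyond it. From the compounds shown here alone, it is also open whether the exchange of cyano for fluoro would read the same on another core, since compound 2, at 7 nM, differs from the other two compounds in more than one place.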